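A few compounds are considered here, and "the series" means these few. Any claim that something is new, unique, unknown or untested is made for them only; others in the source may bear on it.

Three compounds have been measured in a functional assay on NCI-H460 cells (Homo sapiens) for inhibition, read by MTT assay, with a stated time of 72 h; on this read-out lower numbers stand for stronger inhibition and higher numbers for weaker inhibition:

Compound 1, `COc1cc(NC(C)CCCNC(=O)NNC(=O)Nc2cc(C(F)(F)F)cc(C(F)(F)F)c2)c2ncccc2c1`, gives 18000 nM.
Compound 2, `COc1cc(NC(C)CCCNC(=O)Nc2ccc(O)cc2)c2ncccc2c1`, gives 34000 nM.
Compound 3, `COc1cc(NC(C)CCCNC(=O)NNC(=O)Nc2ccc(C(F)(F)F)cc2)c2ncccc2c1`, gives 12000 nM.

Compound 2 carries the highest of these three numbers. Its gap to compound 1 lies within the usual scatter of repeated measurements, so the two cannot be told apart on this read-out. Compound 3, by contrast, gives a number that sits below that of compound 2 by more than the scatter, so compound 3 inhibits more strongly than compound 2 in this assay.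

Compound 4, `COc1cc(NC(C)CCCNC(=O)Nc2cccc(O)c2)c2ncccc2c1`, is the compound that has not yet been measured. It differs from compound 2 in one place only: 3-hydroxyphenyl in place of 4-hydroxyphenyl on an amide-type nitrogen. No measured pair here shows the effect of moving a hydroxyl from one ring position to another on a phenyl urea, so the direction of this change is not fixed by any number shown. The expectation is therefore for a step of no size beyond the scatter, a 1.1-fold lower number from compound 2 to compound 4 (0.05 log units; within the scatter), in this assay. Compound 4 is accordingly estimated at 30000 nM, with a range from 12000 nM to 75000 nM.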

Compound 4, half-maximal inhibitory concentration: 25000 nM
For compound 4 the middle estimate is 1.2-fold (0.08 log units) above the measured one, within the range that was stated.
By their numbers in this assay, from the lowest: compounds 3, 1, 4 and 2 (each within the scatter of the next, the first and the last beyond it).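

In this assay, the step of a 1.4-fold lower number from compound 2 to compound 4 (0.13 log units; within the scatter) shows that 3-hydroxyphenyl and 4-hydroxyphenyl on an amide-type nitrogen cannot be told apart on this read-out. Within the data shown here, the earlier compounds held no pair differing in one place, so this is the first direct reading at this position, and it applies to this one exchange only. Nothing shown here bears on why the two compounds cannot be told apart.

On these data alone, whether an amine or a carboxylic acid in place of the hydroxyl on this phenyl ring would give a number beyond the scatter from that of compound 2 remains open. The compounds shown also leave open what a longer chain between the shared core and the urea would do in this assay.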